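Swapping chloro for methoxy on a fluorinated compound

The source may hold more compounds than are shown below. What is called first, only, known or untested is meant among the compounds shown, and "the series" means these compounds.

Compound 1 `Cc1ccc(Cn2c(/C=C3\SC(=S)N(CC(=O)O)C3=O)nc3cc(Cl)ccc32)cc1`: 2720 nM
Compound 2 `COc1ccc2c(c1)nc(/C=C1\SC(=S)N(CC(=O)O)C1=O)n2Cc1ccc(C)cc1`: 770 nM
Compound 3 `O=C(O)CN1C(=O)/C(=C/c2nc3cc(Cl)ccc3n2Cc2ccccc2F)SC1=S`: 870 nM

In a functional assay on HL-60 cells (Homo sapiens) for cytotoxicity, read by MTT assay, with a stated time of 48 h (a higher number here means a weaker inhibitor, a lower number a stronger inhibitor), compound 3 gives 870 nM, which lies within the scatter of compound 2 at 770 nM, while compound 1 stands clearly higher at 2720 nM. Compound 4 `COc1ccc2c(c1)nc(/C=C1\SC(=S)N(CC(=O)O)C1=O)n2Cc1ccccc1F` differs from compound 3 by methoxy in place of chloro on an aromatic carbon, (methoxy in place of chloro on an aromatic carbon). The same exchange has been measured only once, as a 3.5-fold lower number from compound 1 to compound 2 (0.55 log units; beyond the scatter), and that modest step was seen with 4-methylphenyl rather than 2-fluorophenyl in the molecule. The other measured step, a 3.1-fold lower number from compound 1 to compound 3 (0.50 log units; beyond the scatter), is of similar size, but it concerns the 2-fluorophenyl group and does not test the exchange itself. Whether the two changes add up is not known. Going by the values given here, a modest step towards a lower number is therefore expected in this assay, slightly smaller than the single precedent. The expected change is a 2.7-fold lower number from compound 3 to compound 4 (0.43 log units; beyond the scatter). For compound 4 the estimate is 320 nM, with an expected range of 130 nM to 800 nM.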

Compound 4, half-maximal inhibitory concentration: 3410 nM
Beside the measured number, compound 4's estimate is 11-fold (1.03 log units) below it; the measured number lies above the stated range.
By their numbers in this assay, from the lowest: compounds 2 and 3 (each within the scatter of the next); then compounds 1 and 4 (each within the scatter of the next).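

The exchange of chloro for methoxy on an aromatic carbon now gives a 3.9-fold higher number from compound 3 to compound 4 (0.59 log units; beyond the scatter), so in this assay its direction depends on the group carried on the saturated chain carbon bound to an aromatic nitrogen: the same change on two cores in this assay, a 3.5-fold lower number (0.55 log units; beyond the scatter) from compound 1 to compound 2 and a 3.9-fold higher number (0.59 log units; beyond the scatter) from compound 3 to compound 4, 14-fold (1.14 log units) apart, beyond the scatter of two such steps Read the other way, 2-fluorophenyl in place of 4-methylphenyl gives a 4.4-fold higher number from compound 2 to compound 4 (0.65 log units; beyond the scatter) when methoxy is present, although it lowered the number when chloro was present: the same change on two cores in this assay, a 3.1-fold lower number (0.50 log units; beyond the scatter) from compound 1 to compound 3 and a 4.4-fold higher number (0.65 log units; beyond the scatter) from compound 2 to compound 4, 14-fold (1.14 log units) apart, beyond the scatter of two such steps The two changes therefore do not add up, since compound 2 and compound 3, which each carry only one of them relative to compound 1, sit at the lower numbers, while compound 4, which carries both, does not.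

These four compounds do not show why the two positions are coupled. Going by these compounds, it also remains open whether an amine or a hydroxyl at this aromatic carbon would behave like chloro or like methoxy with each of the two aryl groups.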